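Cyclopropylmethyl ether in place of alkynyl ether

The source may hold more compounds than are shown below. What is called first, only, known or untested is meant among the compounds shown, and "the series" means these compounds.

Compound 1, `Nc1ccc2cccc(OC3CCC3)c2n1`; in an assay on cells with melanin-concentrating hormone receptor 1 (Homo sapiens) as the target, read by radioligand binding (a lower number here means a stronger inhibitor, a higher number a weaker inhibitor), compound 1 gives > 2000 nM, which is a limit of the assay and not a number.
Compound 2, `CC#CCCOc1cccc2ccc(N)nc12`; in this assay compound 2 gives > 2000 nM, again a limit rather than a number.

Among the measured compounds shown here, compound 2 therefore stands only at the limit of > 2000 nM in this assay, at which 2 of the 2 values shown sit, and the one measured step, a step that the two limits leave unreadable from compound 1 to compound 2, cannot be read. Compound 3, `CC1CC1COc1cccc2ccc(N)nc12`, carries 2-methylcyclopropyl in place of but-2-yn-1-yl on a saturated chain carbon bound to an oxygen on an aromatic ring. No readable step bears on this change, so compound 3 is expected to stay near the limit, with an estimated 3000 nM spanning 800 nM to 12000 nM. The expected step that the limit leaves unreadable from compound 2 to compound 3 is thus estimated as none beyond the scatter.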

Compound 3, half-maximal inhibitory concentration: 1640 nM
The estimate for compound 3 lay 1.8-fold (0.26 log units) above the measured number; low and high end bracket the measured number.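

Among the compounds shown here, with (2-methylcyclopropyl)methyl on the oxygen, compound 3 gives the first reading in this assay that is a number and not a limit of the assay. Against the alkynyl ether the change gives an at least 1.2-fold lower number from compound 2 to compound 3 (0.08 log units; that floor lies within the scatter), and against the cyclobutyl ether it gives an at least 1.2-fold lower number from compound 1 to compound 3 (0.08 log units; that floor lies within the scatter), so neither comparison shows a real gain. Going by these compounds, the true size of both steps stays unknown because the values of the other two compounds are limits: the limit of > 2000 nM in this assay, at which 2 of the 3 values shown sit. On these data alone, whether a longer chain or an amine in place of 2-methylcyclopropyl would lower the number further stays open.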